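The compounds below may be only part of what the source reports. "The series", "measured", "known", "first", "only" and "open" are said of these compounds alone.

Compound 1 `CCOC(=O)c1c(-c2cc3ccccc3oc2=O)nn(-c2cccc(C)c2)c1C(=O)OCC`: 47000 nM
Compound 2 `CCOC(=O)c1c(-c2cc3ccccc3oc2=O)nn(-c2ccc(OC)cc2)c1C(=O)OCC`: 39000 nM
Compound 3 `CCOC(=O)c1c(-c2cc3ccccc3oc2=O)nn(-c2ccc(Cl)cc2)c1C(=O)OCC`: 26000 nM

These three compounds were tested in a functional assay on DU-145 cells (Homo sapiens) for cytotoxicity, read by MTT assay, with a stated time of 48 h; on this read-out higher numbers stand for weaker inhibition and lower numbers for stronger inhibition. Compound 1 gives the highest of the three numbers in this assay, yet its nearest neighbour, compound 2, differs by only a 1.2-fold lower number from compound 1 to compound 2 (0.08 log units; within the scatter), and the furthest, compound 3, by a 1.8-fold lower number from compound 1 to compound 3 (0.26 log units; within the scatter); both steps lie within the scatter, so the three compounds count as alike. Compound 4 `CCOC(=O)c1c(-c2cc3cc(OC)ccc3oc2=O)nn(-c2cccc(C)c2)c1C(=O)OCC` has not yet been measured. It differs from compound 1 in one respect: methoxy in place of hydrogen on an aromatic carbon. The steps measured so far, including a 1.5-fold lower number from compound 2 to compound 3 (0.18 log units; within the scatter), all change the group on an aromatic nitrogen and leave the fused ring system untouched, so none bears directly on this change, and every one of them has stayed within the scatter. For compound 4 the expected step is therefore a 1.2-fold lower number from compound 1 to compound 4 (0.07 log units; within the scatter), no larger than the scatter. The estimate for compound 4 in this assay is 40000 nM, with a range from 15000 nM to 110000 nM.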

Compound 4, half-maximal inhibitory concentration: 31000 nM
Compound 4: the middle estimate sits 1.3-fold (0.11 log units) above what was measured; measured number inside the range.
By their numbers in this assay, from the lowest: compounds 3, 4, 2 and 1 (each within the scatter of the next).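

Compound 4 is the first compound shown with a change on the fused ring system rather than on the aromatic nitrogen, and in this assay methoxy in place of hydrogen gives a 1.5-fold lower number from compound 1 to compound 4 (0.18 log units; within the scatter). At this one carbon, then, the added methoxy leaves compound 4 alike with compound 1, just as changing the group on the nitrogen left the earlier compounds alike, so neither site has yet shown a real shift in the number. Nothing available explains this result.

As far as these compounds go, whether an amine, a carboxylic acid or a longer chain at this carbon would move the number beyond the scatter remains open. From the compounds shown here alone, it is also open whether methoxy here would behave the same alongside 4-chlorophenyl or 4-methoxyphenyl on the nitrogen, or on other carbons of that ring.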